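Naphthalen-1-yl for trifluoromethylphenyl: expected cytotoxicity of compound 3

The compounds below may be only part of what the source reports. "The series", "measured", "known", "first", "only" and "open" are said of these compounds alone.

The measured compounds, tested in an ADME assay on A549 cells (Homo sapiens) for cytotoxicity, read by CellTiter-Glo; on this read-out lower numbers stand for higher toxicity in this test and higher numbers for lower toxicity in this test:
Compound 1, `Cc1c(Cc2ccc(F)cc2F)c(=O)oc2cc(OCC(O)CN3CCC(C(N)=O)CC3)ccc12`, gives > 100000 nM, which is a limit of the test rather than a number.
Compound 2, `Cc1c(Cc2ccc(C(F)(F)F)cc2)c(=O)oc2cc(OCC(O)CN3CCC(C(N)=O)CC3)ccc12`, gives 89300 nM.

Among the measured compounds shown here, compound 2 holds the only plain number among the two values shown; the other value is a limit (the limit of > 100000 nM in this assay, at which 1 of the 2 values shown sits). The step of an at least 1.1-fold lower number from compound 1 to compound 2 (0.04 log units; that floor lies within the scatter) is all that the measured pair shows for changes at this position, and its floor lies within the scatter, so it settles neither size nor direction.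

Compound 3, `Cc1c(Cc2cccc3ccccc23)c(=O)oc2cc(OCC(O)CN3CCC(C(N)=O)CC3)ccc12`, differs from compound 2 by naphthalen-1-yl in place of 4-(trifluoromethyl)phenyl on a saturated chain carbon bound to an aromatic carbon. For the measured compounds named here, the only measured step that bears on this change is an at least 1.1-fold lower number from compound 1 to compound 2 (0.04 log units; that floor lies within the scatter), a step whose floor lies within the scatter, and it involves a different pair of aryl groups on the same chain carbon. With so thin a precedent, no shift beyond the scatter in this assay is expected, and the change is estimated as a 1.3-fold lower number from compound 2 to compound 3 (0.11 log units; within the scatter). Compound 3 is therefore expected to give about 70000 nM, within 25000 nM to 150000 nM, with a fair chance that the test again reports only a limit.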

Compound 3, half-maximal cytotoxic concentration: 42400 nM
The estimate for compound 3 lay 1.7-fold (0.22 log units) above the measured number, and the stated range covers the measured number.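

In this assay, changing the aryl group on this saturated chain carbon now gives a step beyond the scatter: a 2.1-fold lower number from compound 2 to compound 3 (0.32 log units; beyond the scatter). Among the compounds shown here, this is the first step at this position with a readable direction, and an at least 2.3-fold lower number from compound 1 to compound 3 (0.37 log units; beyond the scatter) points the same way, so both steps into naphthalen-1-yl lead to a lower number, which in this test means higher toxicity. The second step gives only a floor and not a full size, since the value of compound 1 is a limit of the test: the limit of > 100000 nM in this assay, at which 1 of the 3 values shown sits.

The change from compound 2 to compound 3 removes the three fluorine atoms and brings in a second aromatic ring in a single move, so these compounds cannot show which of the two goes with the lower number. Also open, from the compounds shown here alone, is where an unsubstituted phenyl would fall on this chain carbon, and whether an amine on the aryl ring would move the number in either direction.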